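The compounds below may be only part of what the source reports. "The series", "measured", "known", "first", "only" and "open" are said of these compounds alone.

Measured so far:
compound 1, `Fc1cccc(-c2nc(Nc3cccc(Br)c3)c3cc(F)ccc3n2)c1` — > 50000 nM in a functional assay on U2OS cells (Homo sapiens) for cytotoxicity, read by MTT assay, with a stated time of 48 h; a lower number here means a stronger inhibitor, a higher number a weaker inhibitor
compound 2, `Oc1ccccc1Nc1nc(-c2cccc(F)c2)nc2ccc(F)cc12` — 41400 nM in this assay

Compound 1 gives only a limit in this assay, (the limit of > 50000 nM in this assay, at which 1 of the 2 values shown sits), and not a number. Compound 2 is therefore the only compound with a number shown in this assay, and that number sits far up the scale. Within the data shown here, the one step among the measured pair, an at least 1.2-fold lower number from compound 1 to compound 2 (0.08 log units; that floor lies within the scatter), runs from a limit to a weak number and its floor lies within the scatter, so it carries little weight.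

Compound 3, `Nc1cccc(Nc2nc(-c3cccc(F)c3)nc3ccc(F)cc23)c1`, differs from compound 2 in one place: 3-aminophenyl in place of 2-hydroxyphenyl on a nitrogen on an aromatic ring. Among the measured compounds shown here, the single measured step bearing on a change at this nitrogen gave no movement beyond the scatter. Compound 3 is therefore expected to stay close to compound 2, with the step of a 1.1-fold higher number from compound 2 to compound 3 (0.04 log units; within the scatter) expected to lie within the scatter. Compound 3 is estimated at 45000 nM, with a range from 15000 nM to 150000 nM, and a fair chance that this assay again reports only a limit.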

Compound 3, half-maximal inhibitory concentration: 49700 nM
Compound 3: middle estimate off by 1.1-fold (0.04 log units), on the low side; the range from low to high includes it.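

Among these compounds, replacing 2-hydroxyphenyl with 3-aminophenyl on this nitrogen gives the first step at this position with a number at both ends, and in this assay this change gives a 1.2-fold higher number from compound 2 to compound 3 (0.08 log units; within the scatter). The two groups, which have the same counts of hydrogen-bond donors and acceptors, therefore cannot be told apart here, and both values sit far up the scale. Amino in place of bromo on an aromatic carbon gives a number no higher from compound 1 to compound 3 (the limit leaves the size open), and this step cannot be read. Compound 1 remains a limit: the limit of > 50000 nM in this assay, at which 1 of the 3 values shown sits.

Still open, going by these compounds, is whether any group on this nitrogen can bring the number down substantially, such as a phenyl ring bearing a carboxylic acid, or a longer chain in place of the ring. On these data alone, what a change elsewhere on the shared core would do also remains open.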